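Removing the ring hydroxy from compound 2

This account rests on a few compounds, and the source may have more. Where it says the series, first, only, none or still open, it means among the compounds named here.

In a functional assay on HeLa cells (Homo sapiens) for cytotoxicity, read by colorimetric assay and neutral red uptake, with a stated time of 72 h (on this read-out higher numbers stand for weaker inhibition and lower numbers for stronger inhibition), compound 1 (`CO[C@@H](C(=O)N[C@H]1CCCCNC1=O)[C@H](O)[C@@H](O)[C@H](O)/C=C/C(C)(C)C`) gives 60700 nM as its half-maximal inhibitory concentration. Compound 2 (`CO[C@@H](C(=O)N[C@H]1CC[C@@H](O)CNC1=O)[C@H](O)[C@@H](O)[C@H](O)/C=C/C(C)(C)C`) reads > 150000 nM in this assay and this is a limit of the assay, not a number. Compound 3 (`CO[C@@H](C(=O)N[C@@H]1CCCCNC1=O)[C@H](O)[C@@H](O)[C@H](O)/C=C/C(C)(C)C`) has not been measured yet. Going to it from compound 2, the change is 2-oxoazepan-3-yl in place of 6-hydroxy-2-oxoazepan-3-yl on an amide-type nitrogen and the ring no longer carries its hydroxy group. Among the compounds with values here, the one measured step that bears on this is an at least 2.4-fold higher number from compound 1 to compound 2 (0.39 log units; beyond the scatter) and it came with hydroxy in place of hydrogen on a saturated ring carbon. Read backwards, that step points to a lower number, meaning stronger inhibition, once the hydroxy is gone. Going by these compounds, it is a single step, and its far end is only a limit, so its true size is unknown and the expectation stays loose. The expected change in this assay is an at least 1.8-fold lower number from compound 2 to compound 3 (0.27 log units; that floor lies within the scatter) on this reasoning. The estimated value for compound 3 is 80000 nM with an expected range from 25000 nM to 200000 nM in this read-out.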

Compound 3, half-maximal inhibitory concentration: 2100 nM
Compound 3: middle estimate off by 38-fold (1.58 log units), on the high side; measured number outside the range, below it.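

In this assay the new result gives a 29-fold lower number from compound 1 to compound 3 (1.46 log units; beyond the scatter), and this large step can be put down to the stereocentre at the saturated ring carbon, drawn S in compound 1 and R in compound 3, because nothing else separates the pair: the fact that compounds 1 and 3 differ only in the configuration as drawn. The other new step, an at least 71-fold lower number from compound 2 to compound 3 (1.85 log units; beyond the scatter), combines the loss of the ring hydroxy with a change of configuration, so it cannot be read as the effect of the hydroxy alone. Going by these compounds, compound 2 is held at a limit of the assay rather than a number, so the true size of that step stays unknown: the limit of > 150000 nM in this assay, at which 1 of the 3 values shown sits.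

The compounds shown leave open whether a hydroxy on the ring of compound 3 would weaken inhibition as it does on the ring of compound 1, since the hydroxy step is known only for the configuration of compound 1. They also leave open how an amine or a methoxy group at that ring carbon would read in this assay on the configuration of compound 3.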